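The source may hold more compounds than are shown below. What is called first, only, known or untested is meant among the compounds shown, and "the series" means these compounds.

Measured in a physicochemical assay for lipophilicity, at pH 7.4; a higher number here means a more lipophilic compound, a lower number a more polar compound:
- compound 1 `Cc1cc(C(=O)Nc2ccc(F)cc2)nn1Cc1cc(Cl)ccc1OCc1ccccc1`: 3
- compound 2 `Cc1cc(C(=O)Nc2ccccn2)nn1Cc1cc(Cl)ccc1OCc1ccccc1`: > 3.7

For compound 2, > 3.7 is a limit of the assay and not a number. Compound 3 `Cc1cc(NC(=O)C(C)C)nn1Cc1cc(Cl)ccc1OCc1ccccc1` replaces (pyridin-2-yl)carbamoyl with (isopropylcarbonyl)amino on an aromatic carbon ((isopropylcarbonyl)amino in place of (pyridin-2-yl)carbamoyl on an aromatic carbon). For the measured compounds named here, only one measured step bears on this, a number at least 0.70 log units higher from compound 1 to compound 2 (beyond the scatter), where pyridin-2-yl entered on an amide-type nitrogen. Here pyridin-2-yl leaves, so a downward step of modest size in this assay is expected, though that step covers a different swap. The expected change is a number at least 0.30 log units lower from compound 2 to compound 3 (that floor lies within the scatter). For compound 3 the estimated value is 3.4, with an expected range of 2.8 to 4.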

Compound 3, distribution coefficient: > 3.7
Compound 3 was reported as a limit; the forecaster's own chance of this, stated with the estimate: 25%; middle value at least 0.30 log units from the limit.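

In this assay, compound 3 gives > 3.7, a limit of the assay and not a number. With (isopropylcarbonyl)amino on this aromatic carbon, the group carrying no ring, the reading is a number at least 0.70 log units higher from compound 1 to compound 3 (beyond the scatter), so the aromatic ring of (pyridin-2-yl)carbamoyl is not required for a limit reading here. The step between compound 2 and compound 3 cannot be read, because both stand at the same limit: the limit of > 3.7 in this assay, at which 2 of the 3 values shown sit.

Going by these compounds, the order of compound 2 and compound 3 remains open. On these data alone, whether an amine or a carboxylic acid on this aromatic carbon would bring this assay back to a readable number also remains open.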